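From a saturated ring to a fluorinated aromatic ring

This account rests on a few compounds, and the source may have more. Where it says the series, first, only, none or still open, it means among the compounds named here.

Measured so far in a functional assay on A2780 cells (Homo sapiens) for antiproliferative activity, read by CellTiter-Glo, with a stated time of 4 days (on this read-out higher numbers stand for weaker inhibition and lower numbers for stronger inhibition), are three compounds:
Compound 1 `O=C(Nc1ccc(CN2C(=O)c3ccccc3C2=O)cc1)[C@H]1C[C@@H]1c1cccnc1` gives 27 nM
Compound 2 `CC[C@H](NC(=O)c1ccccc1)c1ccc(NC(=O)[C@H]2C[C@@H]2c2cccnc2)cc1` gives 43 nM
Compound 3 `C[C@H](NC(=O)C1CCOCC1)c1ccc(NC(=O)[C@H]2C[C@@H]2c2cccnc2)cc1` gives 3 nM

Compound 3 at 3 nM has the lowest number of the three and so the strongest inhibition. Its gaps to compound 1 and to compound 2 both lie beyond the usual scatter.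

The next compound to be read is compound 4 `C[C@H](NC(=O)c1ccc(F)cc1)c1ccc(NC(=O)[C@H]2C[C@@H]2c2cccnc2)cc1` and it has no value yet. It differs from compound 3 by one exchange, 4-fluorophenyl in place of oxan-4-yl on a carbonyl carbon.

Within the data shown here, no measured pair shows this exchange alone, so any size of step remains an expectation. Compound 2 at 43 nM also has an aromatic ring of carbon only on that carbonyl carbon, although it differs from compound 3 in a second place as well. On that single hint, a higher number and thus weaker inhibition is expected in this assay, a rise beyond the scatter. The expected change is a 5.0-fold higher number from compound 3 to compound 4 (0.70 log units; beyond the scatter) in this estimate. For compound 4 the estimated value is 15 nM with an expected range of 5 nM to 50 nM in this assay.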

Compound 4, half-maximal inhibitory concentration: 2 nM
Beside the measured number, compound 4's estimate is 7.5-fold (0.88 log units) above it; the whole stated range lies above it.
By their numbers in this assay, from the lowest: compounds 4 and 3 (each within the scatter of the next); then compounds 1 and 2 (each within the scatter of the next).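

In this assay, among these compounds, the exchange of oxan-4-yl for 4-fluorophenyl on a carbonyl carbon gives a 1.5-fold lower number from compound 3 to compound 4 (0.18 log units; within the scatter) and thus leaves the two compounds indistinguishable, which is the first direct reading of this position with everything else held constant. The position therefore accepts both a six-membered non-aromatic ring with a hetero atom and a six-membered aromatic ring of carbon only, and compound 4 stays in the same low range as compound 3 even though the ring oxygen, the one hydrogen-bond acceptor of the group that leaves, is gone. Nothing available gives a reason why the two groups read alike.

Since this single exchange alters the ring and brings in the fluorine together, the compounds shown cannot say what the fluorine itself contributes, and a plain phenyl on the same carbonyl carbon would be needed to separate the two. Also open, going by these compounds, is how far this tolerance extends, for instance to a piperidin-4-yl ring with its amine, to a phenyl ring carrying a carboxylic acid, or to a longer chain in place of a ring.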